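Carboxy chain on the series: expected effect on potency

A few compounds are considered here, and "the series" means these few. Any claim that something is new, unique, unknown or untested is made for them only; others in the source may bear on it.

Notes on the series start from two measured compounds. In a functional assay on NCI-H460 cells (Homo sapiens) for inhibition, with a stated time of 72 h (a lower number here means a stronger inhibitor, a higher number a weaker inhibitor), compound 1 `COc1cc(C(=O)c2ccc3cc[nH]c3c2)cc(OC)c1OC` gives 520 nM and compound 2 `CCCn1ccc2cc(C(=O)c3cc(OC)c(OC)c(OC)c3)ccc21` gives 2000 nM. Compound 2 therefore holds the higher of the two numbers, and the gap between them lies beyond the usual scatter.

The next compound to be measured is compound 3 `COc1cc(C(=O)c2ccc3c(ccn3CCC(=O)O)c2)cc(OC)c1OC`. It departs from compound 2 by carboxy in place of methyl on a saturated chain carbon, two bonds along the chain from an aromatic nitrogen. The propyl chain thus becomes 2-carboxyethyl.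

For the measured compounds named here, no measured compound carries a carboxy group, so the expectation has little support and its range is kept wide. A moderate step beyond the scatter toward a higher number, meaning a weaker inhibitor, is expected in this assay. The reference point for this expectation is compound 2 at 2000 nM. The expected change is a 2.5-fold higher number from compound 2 to compound 3 (0.40 log units; beyond the scatter). For compound 3 the estimated value is 5000 nM, with an expected range of 1500 nM to 20000 nM.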

Compound 3, half-maximal inhibitory concentration: > 10000 nM
Compound 3: only a limit was reported (the forecaster's own chance of this, stated with the estimate: 15%); middle value at least 2.0-fold (0.30 log units) from the limit.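

In this assay compound 3 gives > 10000 nM, which is a limit of the assay and not a number. Carboxy in place of methyl on a saturated chain carbon, two bonds along the chain from an aromatic nitrogen, gives an at least 5.0-fold higher number from compound 2 to compound 3 (0.69 log units; beyond the scatter), so this first look at a change at the end of the chain shows that potency depends on what stands there, and that propyl to 2-carboxyethyl moves toward a weaker inhibitor by more than the scatter. The true size of the step stays unknown, and only its lower bound can be read: the limit of > 10000 nM in this assay, at which 1 of the 3 values shown sits.

From the compounds shown here alone, whether the loss belongs to the carboxylic acid itself remains open, since a methyl ester, a primary amide or an amine at the same chain end would be needed to separate the acid from the mere presence of a heteroatom-bearing group there. The compounds shown also leave open how chain length plays into the result, as a carboxymethyl chain or a longer carboxyalkyl chain on the shared core could give a different reading in this assay.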